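Extending a propyl chain of compound 1 with a nitrile

The source may hold more compounds than are shown below. What is called first, only, known or untested is meant among the compounds shown, and "the series" means these compounds.

Compound 1 `CCCn1nc(C(=O)N[C@H]2COc3ccccc3N(C)C2=S)nc1Cc1ccccc1` was examined in a toxicity assay on HT-29 cells (Homo sapiens) for cytotoxicity; a higher number here means that more compound is tolerated, a lower number that less compound is tolerated. In this assay compound 1 gives > 100000 nM, which is a limit of the assay rather than a number. Compound 2 `CCCCCn1nc(C(=O)N[C@H]2COc3ccccc3N(C)C2=S)nc1Cc1ccccc1` carries a longer chain in the same place; in this assay compound 2 gives > 100000 nM, again a limit. Compound 3 `CC(C)n1nc(C(=O)N[C@H]2COc3ccccc3N(C)C2=S)nc1Cc1ccccc1` carries a branched chain there; in this assay compound 3 gives > 100000 nM, also a limit. The step that the two limits leave unreadable from compound 1 to compound 2, the step that the two limits leave unreadable from compound 1 to compound 3 and the step that the two limits leave unreadable from compound 2 to compound 3 therefore cannot be read, since all three values sit at the limit of > 100000 nM in this assay, at which 3 of the 3 values shown sit. Among the compounds with values here, compound 1 stands at the limit, and no measured step around it is readable.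

Compound 4 `CN1C(=S)[C@@H](NC(=O)c2nc(Cc3ccccc3)n(CCCCCC#N)n2)COc2ccccc21` differs from compound 1 by 2-cyanoethyl in place of hydrogen on a saturated chain carbon, three bonds along the chain from an aromatic nitrogen. Within the data shown here, the two measured steps that alter the same chain, a step that the two limits leave unreadable from compound 1 to compound 2 and a step that the two limits leave unreadable from compound 1 to compound 3, are unreadable, and no measured step introduces a nitrile, so no readable step in this assay tells the direction or size of this change. With every measured compound at the limit, the expectation is that compound 4 also stays at or near the limit, a step of a number no higher from compound 1 to compound 4 (the limit leaves the size open). Compound 4 is accordingly estimated at 100000 nM, with a range from 40000 nM to 300000 nM.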

Compound 4, half-maximal cytotoxic concentration: > 100000 nM
Compound 4 was reported as a limit (the forecaster's own chance of this, stated with the estimate: 80%); the middle value lies on the limit itself.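

In this assay compound 4 gives > 100000 nM as a limit of the assay and not a number. Its steps to compound 1, compound 2 and compound 3 therefore cannot be read: the limit of > 100000 nM in this assay, at which 4 of the 4 values shown sit. The compounds shown leave open whether any change to the chain on the aromatic nitrogen, nitrile included, alters how much compound the cells tolerate.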